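The compounds below may be only part of what the source reports. "The series", "measured", "known", "first", "only" and "open" are said of these compounds alone.

Compound 1, with the structure `Nc1cc(O)ccc1NC(=O)c1ccc(CNc2nccc(-c3cccnc3)n2)cc1`, is the starting point of this account. In an assay for inhibition of histone deacetylase 8 (Homo sapiens), read by fluorescence, with stated times of 15 min and 60 min (on this read-out lower numbers stand for stronger inhibition and higher numbers for weaker inhibition), compound 1 gives only a limit of the assay, > 20000 nM, and not a number. Two further compounds share its amide core. Compound 2, `Nc1ccccc1NC(=O)c1ccc(CNC2=N[C@@H](c3ccc(O)cc3)CS2)cc1`, gives 15000 nM in this assay. Compound 3, `Nc1ccccc1NC(=O)c1ccc(CNC2=NC(=O)C(Cc3c[nH]c4ccccc34)N2)cc1`, reaches only the limit of the assay, > 20000 nM, in this assay. Thus compound 1 stands among weak inhibitors, and the limit of > 20000 nM in this assay, at which 2 of the 3 values shown sit, shows that two of the three values rest at the same limit, so no compound in this set can be ranked against compound 1.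

Compound 4, `CC(C)(C)[Si](C)(C)OCc1ccc(NC(=O)c2ccc(CNc3nccc(-c4cccnc4)n3)cc2)c(N)c1`, has not yet been measured. It differs from compound 1 by a group of 9 heavy atoms (7 carbon, 1 oxygen, 1 silicon; no ring) in place of one oxygen atom, on an aromatic carbon. Among the compounds with values here, no step between two measured compounds with a change of this kind is available, so the direction of any shift cannot be read from the data. The expected step of a number no higher from compound 1 to compound 4 (the limit leaves the size open) is therefore no larger than the scatter of the assay. Compound 4 is expected to give about 20000 nM in this assay, within a range from 5000 nM to 60000 nM.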

Compound 4, half-maximal inhibitory concentration: > 20000 nM
Compound 4: a limit, no number; the forecaster's own chance of this, stated with the estimate: 60%; the middle value sits exactly at the limit.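

Compound 1 and compound 4 both stand at a limit of this assay and not at a number, so no step between them can be read: the limit of > 20000 nM in this assay, at which 3 of the 4 values shown sit.

The compounds shown leave open whether putting this group of 9 heavy atoms in place of the hydroxy changes inhibition at all, in either direction.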